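Halobenzyl variation on a piperidine-oxadiazole hydroxamate series

The source may report more compounds than this note shows. Statements on the series, on what has been measured and on what is new or still open speak of the compounds shown alone.

Measured in an assay on isolated protein for inhibition of protein deacetylase HDAC6 (Homo sapiens), read by fluorescence, with a stated time of 1 h, tested at 100 nM; a lower number here means less inhibition, a higher number more inhibition at the concentration tested (going by the name of the read-out):
compound 1 `CN(Cc1nc(C2CCN(Cc3ccccc3F)CC2)no1)c1ncc(C(=O)NO)cn1` gives 44%
compound 2 `CN(Cc1nc(C2CCN(Cc3ccccc3Cl)CC2)no1)c1ncc(C(=O)NO)cn1` gives 55%
compound 3 `CN(Cc1nc(C2CCN(Cc3ccc(F)cc3F)CC2)no1)c1ncc(C(=O)NO)cn1` gives 66%

The shared core is unchanged across the three; only the benzyl ring differs. The change chloro in place of fluoro on an aromatic carbon gives a number 11 percentage points higher from compound 1 to compound 2 (beyond the scatter). The change fluoro in place of hydrogen on an aromatic carbon gives a number 22 percentage points higher from compound 1 to compound 3 (beyond the scatter). From compound 2 to compound 3, a number 11 percentage points higher from compound 2 to compound 3 (beyond the scatter). Compound 3 stands highest of the three, and both gaps are beyond the scatter.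

Compound 4 `CN(Cc1nc(C2CCN(Cc3ccc(F)cc3Cl)CC2)no1)c1ncc(C(=O)NO)cn1` is not yet measured. It differs from compound 3 by chloro in place of fluoro on an aromatic carbon. This is the same kind of change as from compound 1 to compound 2, which moved the read-out by a number 11 percentage points higher from compound 1 to compound 2 (beyond the scatter); the surroundings differ in that here the place is also meta to a fluoro group, which the earlier step did not have. Compound 3 already stands at 66%. On that single precedent, the expected step is a number 8 percentage points higher from compound 3 to compound 4 (within the scatter), smaller than the earlier one. Compound 4 is therefore estimated at 74% in this assay, with a likely range from 60% to 86%.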

Compound 4, a percentage reported as inhibition, at one concentration (the size of the read-out at that concentration, not a potency): 49%
Beside the measured number, compound 4's estimate is 25 percentage points above it; measured number outside the range, below it.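

In this assay, chloro in place of fluoro on an aromatic carbon gives a number 17 percentage points lower from compound 3 to compound 4 (beyond the scatter), so this change does not carry over unchanged between the two cores: the same change on two cores in this assay, a number 11 percentage points higher (beyond the scatter) from compound 1 to compound 2 and a number 17 percentage points lower (beyond the scatter) from compound 3 to compound 4, 28 percentage points apart, beyond the scatter of two such steps. Fluoro in place of hydrogen on an aromatic carbon gives a number 6 percentage points lower from compound 2 to compound 4 (within the scatter), and it does not carry over unchanged either: the same change on two cores in this assay, a number 22 percentage points higher (beyond the scatter) from compound 1 to compound 3 and a number 6 percentage points lower (within the scatter) from compound 2 to compound 4, 28 percentage points apart, beyond the scatter of two such steps. With 2-chloro-4-fluorophenyl in place of 2-fluorophenyl giving a number 5 percentage points higher from compound 1 to compound 4 (within the scatter), the effect of each change depends on the other substituent in these four compounds, but this rests on one pair of steps per change and shows neither the reason for the mismatch nor how either change behaves on any other benzyl ring.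

Going by these compounds, it remains open whether steps would diverge in the same way with methoxy or trifluoromethyl on the benzyl ring. On these data alone, it is also open whether they would do so with a longer chain joining that ring to the amine nitrogen.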